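Notes on compound 4: trifluoromethoxy in place of trifluoromethyl

The source may report more compounds than this note shows. Statements on the series, on what has been measured and on what is new or still open speak of the compounds shown alone.

In a functional assay on DU-145 cells (Homo sapiens) for antiproliferative activity, read by propidium iodide staining, with a stated time of 96 h (a higher number here means a weaker inhibitor, a lower number a stronger inhibitor), compound 1 (`CC(O)(CSc1ccc(F)cc1)C(=O)Nc1ccc(S(F)(F)(F)(F)F)cc1`) reads 25400 nM and compound 2 (`CC(O)(CSc1cccc(C(F)(F)F)c1)C(=O)Nc1ccc(S(F)(F)(F)(F)F)cc1`) reads 26200 nM while compound 3 (`CC(O)(CSc1ccccc1C(F)(F)F)C(=O)Nc1ccc(S(F)(F)(F)(F)F)cc1`) reads 15800 nM on the same scale. Compound 3 stands level with the other two, since the steps that reach it, a 1.6-fold lower number from compound 1 to compound 3 (0.21 log units; within the scatter) and a 1.7-fold lower number from compound 2 to compound 3 (0.22 log units; within the scatter), both remain within the scatter. The remaining pair shows a 1.0-fold higher number from compound 1 to compound 2 (0.01 log units; within the scatter) and adds no separation.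

Compound 4 (`CC(O)(CSc1ccccc1OC(F)(F)F)C(=O)Nc1ccc(S(F)(F)(F)(F)F)cc1`) comes from compound 3 by a single change, trifluoromethoxy in place of trifluoromethyl on an aromatic carbon, ortho to a large group (trifluoromethoxy in place of trifluoromethyl on an aromatic carbon). For the measured compounds named here, no measured compound carries trifluoromethoxy, so no direct precedent for this swap exists. The nearest guides are the three steps above, each of which changes only the group on the sulfur and none of which leaves the scatter. The series is small, and three compounds cannot show how far this holds. On that evidence, no step beyond the scatter is expected in this assay and no direction can be favoured with confidence. The expected size is a 1.1-fold higher number from compound 3 to compound 4 (0.06 log units; within the scatter) as an estimate only. For compound 4 the estimated value is 18000 nM (expected range 9000 nM to 35000 nM).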

Compound 4, half-maximal inhibitory concentration: 29000 nM
The estimate for compound 4 lay 1.6-fold (0.21 log units) below the measured number; measured number inside the range.
By their numbers in this assay, from the lowest: compounds 3, 1, 2 and 4 (each within the scatter of the next).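

In this assay, for the compounds shown here, trifluoromethoxy in place of trifluoromethyl on an aromatic carbon, ortho to a large group, gives a 1.8-fold higher number from compound 3 to compound 4 (0.26 log units; within the scatter), the first step that keeps the place fixed and changes the group itself. The entering group adds one oxygen and one hydrogen-bond acceptor to the count, and this step still stays within the scatter, so the earlier finding of no separation now extends from changes of the aryl group on the sulfur to a change of the substituent at this one place. No measurement bearing on the reason for this result is available, so the step stands as a bare observation.

Still open, as far as these compounds go, is whether a clearly different group at this place, such as an amine, a carboxylic acid or a longer chain, would produce a step beyond the scatter in this assay. The compounds shown also leave open whether trifluoromethoxy would read the same at another place on this ring or on a different core.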